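Ring change at the carbonyl: compound 2 to compound 3

This account rests on a few compounds, and the source may have more. Where it says the series, first, only, none or still open, it means among the compounds named here.

Compound 1 `CC1CC1C(=O)N1CCc2nc(C#Cc3ccccc3)sc2C1`: in an assay on HEK293 cells for negative allosteric modulation of metabotropic glutamate receptor 5 (Homo sapiens), read by FLIPR, with a stated time of 1 h (a lower number here means a stronger inhibitor, a higher number a weaker inhibitor), compound 1 gives > 10000 nM, a limit.
Compound 2 `O=C(C1CCCCC1)N1CCc2nc(C#Cc3ccccc3)sc2C1`: in this assay compound 2 gives > 10000 nM, a limit.

Compound 2 stands at the assay limit and no number is known for it. Both measured values sit at the same limit (the limit of > 10000 nM in this assay, at which 2 of the 2 values shown sit). Among the compounds with values here, the only measured step, a step that the two limits leave unreadable from compound 1 to compound 2, is therefore unreadable: both ends are limits, so its size and direction cannot be told.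

Compound 3 `O=C(N1CCCCC1)N1CCc2nc(C#Cc3ccccc3)sc2C1` differs from compound 2 in one place: piperidin-1-yl in place of cyclohexyl on a carbonyl carbon.

Within the data shown here, no measured step bears on this change in a readable way. With both neighbours at the limit, the expected step that the limit leaves unreadable from compound 2 to compound 3 for compound 3 is therefore set near no change, and a limit is the most likely outcome. Compound 3 is expected at about 15000 nM, with a range of 4000 nM to 60000 nM.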

Compound 3, half-maximal inhibitory concentration: > 10000 nM
Compound 3 ended at the assay's limit; the forecaster's own chance of this, stated with the estimate: 80%; the middle value is on the limit's open side.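

No new step can be read from compound 3: its steps from compound 1 and compound 2 both join limits, so neither size nor direction is known: the limit of > 10000 nM in this assay, at which 3 of the 3 values shown sit.

The compounds shown leave open which group on the carbonyl carbon, if any, gives a measurable value in this assay.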